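Weakly cytotoxic anilides: 2,4-dimethylphenyl to 2,6-difluorophenyl

The source may report more compounds than this note shows. Statements on the series, on what has been measured and on what is new or still open speak of the compounds shown alone.

Measured so far:
compound 1 `Cc1ccc(NC(=O)CN2CCN(c3nnc(Cc4ccncc4)c4ccccc34)CC2)c(C)c1` 45000 nM
compound 2 `O=C(CN1CCN(c2nnc(Cc3ccccc3)c3ccccc23)CC1)Nc1cc(C(F)(F)F)ccc1Cl` 89000 nM

In a functional assay on A549 cells (Homo sapiens) for cytotoxicity, read by MTT assay, with a stated time of 72 h (a higher number here means a weaker inhibitor, a lower number a stronger inhibitor), compound 1 gives 45000 nM, the lowest of the two numbers recorded. In this assay compound 2 gives 89000 nM, and the gap between the two values lies within the scatter, so no order between them can be read. Among the compounds with values here, no pair of measured compounds differing in a single place is available, so the series gives no calibrated step from which to judge the size of a change at the amide-type nitrogen.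

Compound 3 `O=C(CN1CCN(c2nnc(Cc3ccncc3)c3ccccc23)CC1)Nc1c(F)cccc1F` differs from compound 1 by 2,6-difluorophenyl in place of 2,4-dimethylphenyl on an amide-type nitrogen. Both measured compounds sit at high concentrations in this assay, and nothing in the two numbers points to a direction for this change. The estimate for compound 3 in this assay is 50000 nM, with a range from 15000 nM to 150000 nM. The expected step of a 1.1-fold higher number from compound 1 to compound 3 (0.05 log units; within the scatter) is taken as none beyond the scatter.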

Compound 3, half-maximal inhibitory concentration: 54400 nM
Compound 3: the middle estimate sits 1.1-fold (0.04 log units) below what was measured; low and high end bracket the measured number.
By their numbers in this assay, from the lowest: compounds 1, 3 and 2 (each within the scatter of the next).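

The series now has its first calibrated step at the amide-type nitrogen: in this assay, 2,6-difluorophenyl in place of 2,4-dimethylphenyl gives (a 1.2-fold higher number from compound 1 to compound 3 (0.08 log units; within the scatter)). For this one pair, the exchange of one substituted phenyl for the other produces no change that can be separated from the scatter, so this position tolerates this swap without a readable shift in the cytotoxicity number. No measured property bears on this result, and the data offer no explanation for it.

Still open, going by these compounds, is whether an amine or a carboxylic acid on the phenyl, or a cyclohexyl group in its place on the amide-type nitrogen, would move the number beyond the scatter. Changes elsewhere on the core of compound 1 also remain unresolved, since compound 2 differs from it in more than one place.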